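Cyclopropyl for Ethyl on Two Cores in Microsomal Stability

The source may report more compounds than this note shows. Statements on the series, on what has been measured and on what is new or still open speak of the compounds shown alone.

Compound 1, `CCCN(Cc1ccc(OCCN2C(=O)CCC2=O)c(C)c1)[C@@H](CC(=O)O)c1ccc(Cl)cc1`: 97%
Compound 2, `Cc1cc(CN(CC2CC2)[C@@H](CC(=O)O)c2ccc(Cl)cc2)ccc1OCCN1C(=O)CCC1=O`: 87%
Compound 3, `CCCN(Cc1ccc(OCCn2c(=O)ccn(C)c2=O)c(C)c1)C(CC(=O)O)c1ccc(Cl)cc1`: 23%

Of the compounds shown here, three have been measured in an ADME assay on liver (Mus musculus) for metabolic stability, read by LC-MS, using microsomes and NADPH; a lower number here means that less of the compound is left, a higher number that more of the compound is left. Compound 1 gives 97%, compound 2 gives 87%, and compound 3 gives 23%. Compound 1 and compound 2 share a core and differ by cyclopropyl in place of ethyl on a saturated chain carbon bound to an amine nitrogen; this step reads a number 10 percentage points lower from compound 1 to compound 2 (within the scatter). Compound 3 sits on another core, and the difference between the two cores is not broken down here. Its number is the lowest of the three, beyond the scatter from both others.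

Compound 4, `Cc1cc(CN(CC2CC2)C(CC(=O)O)c2ccc(Cl)cc2)ccc1OCCn1c(=O)ccn(C)c1=O`, has not yet been measured in this assay. It differs from compound 3 by cyclopropyl in place of ethyl on a saturated chain carbon bound to an amine nitrogen, the same change as that between compound 1 and compound 2. Resting on a number 10 percentage points lower from compound 1 to compound 2 (within the scatter), compound 4 is expected to show a number 5 percentage points lower from compound 3 to compound 4 (within the scatter). Compound 4 is therefore estimated at 18%, between 5% and 35%.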

Compound 4, percent of the compound remaining: 24%
Compound 4: middle estimate off by 6 percentage points, on the low side, within the range that was stated.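

In this assay cyclopropyl in place of ethyl on a saturated chain carbon bound to an amine nitrogen gives a number 1 percentage points higher from compound 3 to compound 4 (within the scatter) and agrees with the earlier step: the same change on two cores in this assay, a number 10 percentage points lower (within the scatter) from compound 1 to compound 2 and a number 1 percentage points higher (within the scatter) from compound 3 to compound 4, 11 percentage points apart, within the scatter of two such steps. On these two cores, the change therefore carries over without any difference beyond the scatter. This does not show that the change has a real effect in either direction on either core, and two pairs say nothing about a further core.

The compounds shown leave open what a longer chain or a cyclobutyl group would give at the same place in this assay. They also leave open how the change would read with an ester in place of the carboxylic acid.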